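Swapping the Amide Aryl Group on a Shared Core

A few compounds are considered here, and "the series" means these few. Any claim that something is new, unique, unknown or untested is made for them only; others in the source may bear on it.

Of the compounds shown here, two of one core have been measured. Compound 1 `O=C(Nc1ccc(Cl)c(-c2nnc3c(Cl)cccn23)c1)c1ccc(C(F)(F)F)cc1Cl` was tested in a functional assay on AN3-CA cells (Homo sapiens) for antiproliferative activity, read by MTT assay, with a stated time of 72 h (a lower number here means a stronger inhibitor, a higher number a weaker inhibitor), and gives only the limit > 100000 nM rather than a number. Compound 2 `O=C(Nc1ccc(Cl)c(-c2nnc3c(Cl)cccn23)c1)c1ccccn1` likewise gives only the limit > 100000 nM in this assay. Compound 2 thus stands at the edge of what the assay can report, where both values shown sit (the limit of > 100000 nM in this assay, at which 2 of the 2 values shown sit). Compound 3 `O=C(Nc1ccc(Cl)c(-c2nnc3c(Cl)cccn23)c1)c1ccc(Cl)cc1` differs from compound 2 by 4-chlorophenyl in place of pyridin-2-yl on a carbonyl carbon. For the measured compounds named here, no measured step exists here, so the expected step in this assay is a number no higher from compound 2 to compound 3 (the limit leaves the size open), none beyond the scatter. Compound 3 is therefore estimated at 100000 nM, ranging from 20000 nM to 300000 nM, and may again return only a limit.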

Compound 3, half-maximal inhibitory concentration: > 100000 nM
Compound 3: no number, only a limit (the forecaster's own chance of this, stated with the estimate: 75%); the middle value sits exactly at the limit.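

Compound 2 and compound 3 both return only a limit of the assay, so no step can be read between them. The compounds shown leave open whether any amide aryl group on the shared core gives a measurable value in this assay at all.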